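This account rests on a few compounds, and the source may have more. Where it says the series, first, only, none or still open, it means among the compounds named here.

Measured so far:
compound 1, `CO[C@@H]1C/C=C(\C)C(=O)N(C)[C@@H](C(C)C)C(=O)N[C@H](Cc2cc(Cl)c(O)c(Cl)c2)C(=O)N[C@@H](C(C)C)C(=O)O[C@H](c2ccccc2)[C@H](C)/C=C/C=C/1C` — 42.1 nM
compound 2, `CC[C@H](C)[C@H]1C(=O)N[C@H](Cc2cc(Cl)c(O)c(Cl)c2)C(=O)N[C@@H](C(C)(C)O)C(=O)O[C@H](c2ccccc2)[C@H](C)/C=C/C=C(\C)[C@H](OC)C[C@@H]2O[C@@]2(C)C(=O)N1C` — 17 nM
compound 3, `CO[C@@H]1C[C@@H]2O[C@@]2(C)C(=O)N(C)[C@@H](C(C)C)C(=O)N[C@H](Cc2cc(Cl)c(O)c(Cl)c2)C(=O)N[C@@H](C(C)(C)O)C(=O)O[C@H](c2ccccc2)[C@H](C)/C=C/C=C/1C` — 6.7 nM

In a functional assay on HCT-116 cells (Homo sapiens) for antiproliferative activity, read by MTT assay, with a stated time of 72 h (a higher number here means a weaker inhibitor, a lower number a stronger inhibitor), compound 3 gives 6.7 nM and compound 2 gives 17 nM. The change from compound 3 to compound 2 is methyl in place of hydrogen on a saturated chain carbon, two bonds along the chain from a saturated ring carbon, and it made a 2.5-fold higher number from compound 3 to compound 2 (0.40 log units; beyond the scatter). Compound 1 gives 42.1 nM, the highest of the three numbers; the difference between the core of compound 1 and the core of compound 3 is not broken down here, so nothing is taken from that pair beyond what the two values show.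

Compound 4, `CC/C1=C\C=C\[C@@H](C)[C@@H](c2ccccc2)OC(=O)[C@H](C(C)C)NC(=O)[C@@H](Cc2cc(Cl)c(O)c(Cl)c2)NC(=O)[C@H](C(C)C)N(C)C(=O)/C(C)=C/C[C@H]1OC`, has not yet been measured in this assay. It differs from compound 1 by methyl in place of hydrogen on a saturated chain carbon bound to a double-bonded ring carbon. Within the data shown here, this is the same kind of change as the one from compound 3 to compound 2, but not the same change: there the place is on a saturated chain carbon, two bonds along the chain from a saturated ring carbon, whereas here it is on a saturated chain carbon bound to a double-bonded ring carbon.

Beside a 2.5-fold higher number from compound 3 to compound 2 (0.40 log units; beyond the scatter), the expected step in this assay from compound 1 to compound 4 is a 1.9-fold higher number from compound 1 to compound 4 (0.28 log units; within the scatter); this expectation rests on the step from compound 3 to compound 2 being a 2.5-fold higher number from compound 3 to compound 2 (0.40 log units; beyond the scatter), while the unlike surroundings of the place leave the size uncertain. Compound 4 is therefore expected to give about 80 nM, most likely between 35 nM and 200 nM.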

Compound 4, half-maximal inhibitory concentration: 60.3 nM
For compound 4 the middle estimate is 1.3-fold (0.12 log units) above the measured one; the range from low to high includes it.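

In this assay, methyl in place of hydrogen can now be read on two cores, and on the core of compound 1 it amounts to a 1.4-fold higher number from compound 1 to compound 4 (0.16 log units; within the scatter), which leaves compound 4 and compound 1 indistinguishable. On the other core the step is a 2.5-fold higher number from compound 3 to compound 2 (0.40 log units; beyond the scatter), yet the two steps themselves cannot be told apart, so the pairs give no sign that the outcome of this change depends on the core: the same change on two cores in this assay, a 2.5-fold higher number (0.40 log units; beyond the scatter) from compound 3 to compound 2 and a 1.4-fold higher number (0.16 log units; within the scatter) from compound 1 to compound 4, 1.8-fold (0.25 log units) apart, within the scatter of two such steps. This does not establish that the step carries over at a fixed size, since each core supplies a single pair and the change sits at unlike places, on a saturated chain carbon two bonds along the chain from a saturated ring carbon in one and on a saturated chain carbon bound to a double-bonded ring carbon in the other.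

The compounds shown leave open how methyl to ethyl would read at that second place on the core of compound 3, which would test the same change at the same place on a different core. They also leave open what a longer chain such as propyl, or a chain ending in a hydroxyl group or an amine, would give at either place.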